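Swapping the Oxazolidinone Arm for a Pyridyl Pyrrolidinone

The source may hold more compounds than are shown below. What is called first, only, known or untested is meant among the compounds shown, and "the series" means these compounds.

Compound 1 `O=C1OC(c2ccccc2)CN1c1cnn2c1CN(C(=O)Nc1cc(F)c(F)c(F)c1)C(C1CC1)C2`: 7410 nM
Compound 2 `O=C1CC(c2cnc(C(F)(F)F)s2)CN1c1cnn2c1CN(C(=O)Nc1cc(F)c(F)c(F)c1)C(C1CC1)C2`: 38500 nM
Compound 3 `C[C@H]1Cn2ncc(N3CC(c4ccccc4)CC3=O)c2CN1C(=S)Nc1cc(F)c(F)c(F)c1`: > 2000 nM (a limit)

In a toxicity assay on HepG2 2.2.15 cells (Homo sapiens) for cytotoxicity, read by CellTiter-Glo (a higher number here means that more compound is tolerated, a lower number that less compound is tolerated), compound 1 gives 7410 nM, the lowest of the two numbers measured. Compound 2 gives 38500 nM in this assay, a higher number that lies beyond the scatter of repeated runs. For compound 3, this assay reports only a limit, > 2000 nM, and no number.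

Compound 4 `O=C1CC(c2ccccn2)CN1c1cnn2c1CN(C(=O)Nc1cc(F)c(F)c(F)c1)C(C1CC1)C2` has not yet been measured. It differs from compound 1 in one place: 2-oxo-4-(pyridin-2-yl)pyrrolidin-1-yl in place of 2-oxo-5-phenyl-1,3-oxazolidin-3-yl on an aromatic carbon

Going by the values given here, with no measured step of this kind to lean on, a modest rise in the tolerated concentration is expected, a 2.0-fold higher number from compound 1 to compound 4 (0.31 log units; beyond the scatter), of a size only a little beyond the scatter. Compound 4 is accordingly estimated at 15000 nM, expected to fall between 5000 nM and 45000 nM.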

Compound 4, half-maximal cytotoxic concentration: 96200 nM
The estimate for compound 4 lay 6.4-fold (0.81 log units) below the measured number; measured number outside the range, above it.
By their numbers in this assay, from the lowest: compound 1; then compound 2; then compound 4.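

In this assay, 2-oxo-4-(pyridin-2-yl)pyrrolidin-1-yl in place of 2-oxo-5-phenyl-1,3-oxazolidin-3-yl gives a 13-fold higher number from compound 1 to compound 4 (1.11 log units; beyond the scatter), so this aromatic carbon of the shared core carries a change with a large effect on the tolerated concentration. The group on the saturated ring carbon also counts, since pyridin-2-yl in place of 2-(trifluoromethyl)-1,3-thiazol-5-yl gives a 2.5-fold higher number from compound 2 to compound 4 (0.40 log units; beyond the scatter). Nothing at hand explains either rise. On these data alone, compound 4 changes both the five-membered ring and the aromatic ring relative to compound 1, so the share of each remains open. Also open, as far as these compounds go, is how an amine or a carboxylic acid on the pyridin-2-yl ring would read in this assay.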